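A Smaller Nitrogen Ring at the Chain End

This account rests on a few compounds, and the source may have more. Where it says the series, first, only, none or still open, it means among the compounds named here.

Of the compounds shown here, two sharing one core have been tested in a functional assay on BCG823 cells (Homo sapiens) for antiproliferative activity, read by MTT assay, with a stated time of 48 h; on this read-out lower numbers stand for stronger inhibition and higher numbers for weaker inhibition. Compound 1 `O=c1cc(-c2ccccc2)oc2cc(OCc3ccccc3)c(OCCCCN3CCCCC3)c(O)c12` gives 3000 nM. Compound 2 `O=c1cc(-c2ccccc2)oc2cc(OCc3ccccc3)c(OCCCN3CCCCC3)c(O)c12`, which carries a shorter chain, gives 4600 nM; the step of a 1.5-fold higher number from compound 1 to compound 2 (0.19 log units; within the scatter) keeps the pair within the usual scatter, so compound 2 simply holds the higher of the two numbers and cannot be told apart from compound 1. Compound 3 `O=c1cc(-c2ccccc2)oc2cc(OCc3ccccc3)c(OCCCN3CCCC3)c(O)c12` has not yet been measured. It differs from compound 2 by pyrrolidin-1-yl in place of piperidin-1-yl on a saturated chain carbon, three bonds along the chain from an oxygen on an aromatic ring. For the measured compounds named here, no measured step involves this exchange of ring size; the single step available concerns chain length and stays within the scatter. On that basis no change beyond the scatter is expected for compound 3, that is no change at the digits printed from compound 2 to compound 3 (within the scatter). Compound 3 is therefore estimated in this assay at 4600 nM, with a range from 1500 nM to 14000 nM.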

Compound 3, half-maximal inhibitory concentration: > 100000 nM
Compound 3 gave a limit, no number; the forecaster's own chance of this, stated with the estimate: 5%; middle value at least 21-fold (1.33 log units) from the limit.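

In this assay compound 3 gives a limit of the assay, not a number: the limit of > 100000 nM in this assay, at which 1 of the 3 values shown sits.

Even so, the result shows that the ring at the end of the chain matters here: pyrrolidin-1-yl in place of piperidin-1-yl gives an at least 21-fold higher number from compound 2 to compound 3 (1.33 log units; beyond the scatter), while the only earlier step, a change in chain length, stayed within the scatter. The gap to the compound with the longer chain is similar in kind, an at least 33-fold higher number from compound 1 to compound 3 (1.52 log units; beyond the scatter), so at this position a five-membered ring separates far more sharply than the chain change did.

The compounds shown do not tell why this exchange has so large an effect, or whether pyrrolidin-1-yl on the longer chain of compound 1 would behave the same way. Going by these compounds, how other groups at the chain end, such as morpholin-4-yl or a dimethylamino group, would read also stays open.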